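Bromo for methoxy on a phenylurea herbicide probe

This account rests on a few compounds, and the source may have more. Where it says the series, first, only, none or still open, it means among the compounds named here.

Measured compounds:
- compound 1, `COc1cccc(NC(=O)N[C@H](C)c2ccccc2)c1`: 92%
- compound 2, `COc1cccc(NC(=O)N[C@@H](C)c2ccccc2)c1`: 99%

In an ADME assay on the whole organism with Oryza sativa as the target, tested at 1 uM (on this read-out higher numbers stand for a weaker effect at the one concentration tested and lower numbers for a stronger effect), compound 2 gives 99%, which is the highest of the two numbers. For the measured compounds named here, its nearest neighbour is compound 1 with 92%; the step of a number 7 percentage points higher from compound 1 to compound 2 (within the scatter) is within the scatter, which fits (the fact that compounds 1 and 2 differ only in the configuration as drawn), the only change between them being the configuration drawn at the stereocentre.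

Compound 3, `C[C@H](NC(=O)Nc1cccc(Br)c1)c1ccccc1`, has not yet been measured. It differs from compound 2 by bromo in place of methoxy on an aromatic carbon. Going by the values given here, no measured step touches this substitution: the one step known concerns configuration only, and it was small. There is therefore no basis for a directed expectation; the account is written before the number is known, and a step of a number 4 percentage points lower from compound 2 to compound 3 (within the scatter) is expected, not beyond the scatter. Compound 3 is estimated at 95%, with a range from 72% to 100%.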

Compound 3, a percentage reported as activity, at one concentration (the size of the read-out at that concentration, not a potency): 100%
Beside the measured number, compound 3's estimate is 5 percentage points below it, within the range that was stated.
By their numbers in this assay, from the lowest: compounds 1, 2 and 3 (each within the scatter of the next).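

In this assay, replacing methoxy with bromo on this aromatic carbon, meta to a large group, gives a number 1 percentage points higher from compound 2 to compound 3 (within the scatter) and so leaves the read-out unmoved beyond the scatter. For the compounds shown here, the earlier pair spoke only to configuration at the stereocentre, whereas this is the first view of a change of substituent at this place: a group with one hydrogen-bond acceptor leaves, one with none enters, and the two cannot be told apart on this read-out. Nothing known about these compounds bears on why the swap makes so little difference.

With only methoxy and bromo shown at this place, it remains open whether an amine or a carboxylic acid there would shift the number beyond the scatter. On these data alone, it also remains open whether any change to the shared core would produce a stronger effect at the one concentration tested.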